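The source may report more compounds than this note shows. Statements on the series, on what has been measured and on what is new or still open speak of the compounds shown alone.

Measured in a functional assay on MKN-45 cells (Homo sapiens) for cytotoxicity, read by MTT assay, with a stated time of 72 h; on this read-out higher numbers stand for weaker inhibition and lower numbers for stronger inhibition:

Compound 1, `COc1cccc(-c2cc(C(=O)Nc3ccc(Oc4ccnc5cc(OCCCN6CCCCC6)c(OC)cc45)c(F)c3)c3ccccc3n2)c1`: 360 nM
Compound 2, `COc1cccc(-c2cc(C(=O)Nc3ccc(Oc4ccnc5cc(OCCCN6CCCC6)c(OC)cc45)c(F)c3)c3ccccc3n2)c1`: 430 nM
Compound 3, `COc1cc2c(Oc3ccc(NC(=O)c4cc(-c5ccccc5)nc5ccc(F)cc45)cc3F)ccnc2cc1OCCCN1CCCCC1`: 30 nM

Compound 4, `COc1cc2c(Oc3ccc(NC(=O)c4cc(-c5ccccc5)nc5ccc(F)cc45)cc3F)ccnc2cc1OCCCN1CCCC1`, has not yet been measured in this assay. Compound 3 stands lowest of the three measured numbers, with compound 1 and compound 2 both well beyond the scatter above it; how the core of compound 3 differs from the core of compound 1 is not broken down here. The change from compound 3 to compound 4 is pyrrolidin-1-yl in place of piperidin-1-yl on a saturated chain carbon, three bonds along the chain from an oxygen on an aromatic ring. The same change, (pyrrolidin-1-yl in place of piperidin-1-yl on a saturated chain carbon, three bonds along the chain from an oxygen on an aromatic ring), has been measured once, where it gave a 1.2-fold higher number from compound 1 to compound 2 (0.08 log units; within the scatter). On that basis compound 4 is expected to stay close to compound 3 in this assay, with an estimated step of a 1.2-fold higher number from compound 3 to compound 4 (0.08 log units; within the scatter), because the earlier step of a 1.2-fold higher number from compound 1 to compound 2 (0.08 log units; within the scatter) lay within the scatter. Compound 4 is therefore estimated at 36 nM, between 18 nM and 75 nM.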

Compound 4, half-maximal inhibitory concentration: 110 nM
Estimate against measurement, compound 4: 3.1-fold (0.49 log units) below, and the stated range ends below it.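

On the core of compound 3, pyrrolidin-1-yl in place of piperidin-1-yl gives a 3.7-fold higher number from compound 3 to compound 4 (0.56 log units; beyond the scatter) in this assay, and this step does not match the earlier one on the other core: the same change on two cores in this assay, a 1.2-fold higher number (0.08 log units; within the scatter) from compound 1 to compound 2 and a 3.7-fold higher number (0.56 log units; beyond the scatter) from compound 3 to compound 4, 3.1-fold (0.49 log units) apart, beyond the scatter of two such steps. In these two pairs, then, the size of the step depends on the core, and the result on one core did not transfer reliably to the other. Two pairs do not show which feature of the cores matters, or how the change would behave on a further core.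

From the compounds shown here alone, it remains open whether a morpholin-4-yl or dimethylamino group in the same place would also differ between the cores. The same question stands for a chain longer than propyl.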